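Trimming a Naphthyloxy Arm Down to a Phenyl Group

This account rests on a few compounds, and the source may have more. Where it says the series, first, only, none or still open, it means among the compounds named here.

Compound 1 `CCn1cc(-c2nnc(COc3cccc4ccccc34)o2)c(=O)c2cc(F)c(N3CCNCC3)cc21`: 127 ug/mL
Compound 2 `CCn1cc(-c2nnc(-c3ccc(Nc4ccccc4)cc3)o2)c(=O)c2cc(F)c(N3CCNCC3)cc21`: 88.6 ug/mL

Both compounds share one core and were tested in a functional assay on A549 cells (Homo sapiens) for cytotoxicity, read by MTT assay; a lower number here means a stronger inhibitor, a higher number a weaker inhibitor. The numbers for compound 1 and compound 2 lie within the usual scatter of each other, so nothing separates them. Compound 3 `CCn1cc(-c2nnc(Cc3ccccc3)o2)c(=O)c2cc(F)c(N3CCNCC3)cc21` differs from compound 1 by phenyl in place of (naphthalen-1-yl)oxy on a saturated chain carbon bound to an aromatic carbon. Going by the values given here, no measured pair shows a change of this kind, so the direction rests on judgement alone. The expected step is a 1.3-fold higher number from compound 1 to compound 3 (0.10 log units; within the scatter), a slight shift toward a higher number that may well stay inside the scatter. Compound 3 is therefore estimated at 160 ug/mL, with a range from 70 ug/mL to 350 ug/mL.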

Compound 3, half-maximal inhibitory concentration: 118 ug/mL
Beside the measured number, compound 3's estimate is 1.4-fold (0.13 log units) above it; measured number inside the range.
By their numbers in this assay, from the lowest: compounds 2, 3 and 1 (each within the scatter of the next).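

In this assay, phenyl in place of (naphthalen-1-yl)oxy on a saturated chain carbon bound to an aromatic carbon gives a 1.1-fold lower number from compound 1 to compound 3 (0.03 log units; within the scatter) and so no readable change. At this position, then, one six-membered aromatic ring and the hydrogen-bond acceptor can go without a visible effect on the number. No supporting data are available to explain this flat result.

As far as these compounds go, whether an amine or a carboxylic acid in place of phenyl would move the number beyond the scatter remains open. So does the effect of a longer chain.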